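A few compounds are considered here, and "the series" means these few. Any claim that something is new, unique, unknown or untested is made for them only; others in the source may bear on it.

Measured so far in a functional assay on Jurkat cells (Homo sapiens) for inhibition; on this read-out higher numbers stand for weaker inhibition and lower numbers for stronger inhibition:
compound 1 `CC(C)[C@H](NC(=O)COc1cccc2ccccc12)C(=O)N[C@@H](CC(=O)O)C(=O)CSc1nc(-c2ccccc2)c(-c2ccccc2)[nH]1`: > 200000 nM
compound 2 `CC(C)[C@H](NC(=O)COc1cccc2ccccc12)C(=O)N[C@@H](CC(=O)O)C(=O)CSc1nc(-c2ccccc2)c(-c2ccccc2)o1`: > 200000 nM
compound 3 `CC(C)[C@H](NC(=O)COc1cccc2ccccc12)C(=O)N[C@@H](CC(=O)O)C(=O)CSc1nc2ccccc2[nH]1`: > 200000 nM

Compound 3 gives only a limit of the assay in this assay, not a number. Within the data shown here, the same holds for the other two values shown, so that (the limit of > 200000 nM in this assay, at which 3 of the 3 values shown sit); no measured step between these compounds exists, and nothing separates compound 3 from compound 1 or compound 2 on the numbers.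

The change to compound 4 `CC(C)[C@H](NC(=O)COc1cccc2ccccc12)C(=O)N[C@@H](CC(=O)O)C(=O)COc1cncc2ccccc12` is (isoquinolin-4-yl)oxy in place of (1H-benzimidazol-2-yl)sulfanyl on a saturated chain carbon bound to a carbonyl carbon.

With every shown value a limit, no step size can be scaled from the data; the expected step is none beyond the scatter, with compound 4 most likely again reported only as a limit. Compound 4 is thus estimated at 200000 nM, range 30000 nM to 400000 nM, meaning an expected step of a number no higher from compound 3 to compound 4 (the limit leaves the size open).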

Compound 4, half-maximal inhibitory concentration: 166000 nM
Compound 4: middle estimate off by 1.2-fold (0.08 log units), on the high side; the measured number falls inside the stated range.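

In this assay, (isoquinolin-4-yl)oxy in place of (1H-benzimidazol-2-yl)sulfanyl on a saturated chain carbon bound to a carbonyl carbon gives an at least 1.2-fold lower number from compound 3 to compound 4 (0.08 log units; that floor lies within the scatter). Among these compounds, compound 4 is the first to return a number rather than a limit, so a change at this place can bring a readable value. The true size of the step cannot be read, and most values remain at a limit: the limit of > 200000 nM in this assay, at which 3 of the 4 values shown sit.

On these data alone, the oxygen link and the isoquinolin-4-yl group enter together, so their separate contributions remain open. Also open, as far as these compounds go, is how an amine or a longer chain would read at this place.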